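The source may report more compounds than this note shows. Statements on the series, on what has been measured and on what is new or still open speak of the compounds shown alone.

Compound 1 `Brc1cn2ccnc2c(-c2ccc3ncn(C4CCCCC4)c3c2)n1` gives 6.6% in a functional assay on IGROV-1 cells (Homo sapiens) for inhibition, read by sulforhodamine B assay, with a stated time of 48 h, tested at 10 uM; on this read-out lower numbers stand for less inhibition and higher numbers for more inhibition at the one concentration tested (going by the name of the read-out).
Compound 2 `COc1ccc(-c2cn3ccnc3c(-c3ccc4ncn(C5CCCCC5)c4c3)n2)cc1` gives 53.4% in this assay.
Compound 3 `O=Cc1ccc(-c2cn3ccnc3c(-c3ccc4ncn(C5CCCCC5)c4c3)n2)cc1` gives 21.3% in this assay.

Among these three numbers compound 3 stands second highest. Its nearest neighbour is compound 1, separated by the step of a number 14.7 percentage points higher from compound 1 to compound 3 (beyond the scatter); its furthest is compound 2, separated by the step of a number 32.1 percentage points lower from compound 2 to compound 3 (beyond the scatter).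

Compound 4 `c1cn2cc(-c3ccsc3)nc(-c3ccc4ncn(C5CCCCC5)c4c3)c2n1` differs from compound 3 in one place: thiophen-3-yl in place of 4-formylphenyl on an aromatic carbon. The measured steps that bear on this change are those altering the group at the same aromatic carbon: a number 46.8 percentage points higher from compound 1 to compound 2 (beyond the scatter), a number 14.7 percentage points higher from compound 1 to compound 3 (beyond the scatter) and a number 32.1 percentage points lower from compound 2 to compound 3 (beyond the scatter). Both six-membered aryl groups raised inhibition above the bromo compound, but the two aryls are far apart from each other, so the size of an aryl effect here is unsettled. Going by the values given here, no measured step exchanges a six-membered aryl for a five-membered ring, so no direct guide exists. The writer therefore expects a step of a number 8.7 percentage points higher from compound 3 to compound 4 (within the scatter), with wide uncertainty. Compound 4 is expected to give 30% in this assay, between 8% and 58%.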

Compound 4, a percentage reported as inhibition, at one concentration (the size of the read-out at that concentration, not a potency): 1.51%
Beside the measured number, compound 4's estimate is 28.5 percentage points above it, and the stated range ends above it.
By their numbers in this assay, from the lowest: compounds 4 and 1 (each within the scatter of the next); then compound 3; then compound 2.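

In this assay, an aromatic ring at this carbon is not enough for inhibition: thiophen-3-yl gives a number 19.8 percentage points lower from compound 3 to compound 4 (beyond the scatter) and a number 51.9 percentage points lower from compound 2 to compound 4 (beyond the scatter), so the rise seen with the two six-membered aryl groups does not extend to this five-membered ring. With a number 5.1 percentage points lower from compound 1 to compound 4 (within the scatter), thiophen-3-yl cannot be told apart from bromo at this position. Nothing measured here explains why the five-membered ring falls short of the two aryl groups.

On these data alone, it remains open whether the low number goes with the five-membered ring itself or with the absence of a further substituent on it, which an unsubstituted phenyl or a methoxy-bearing thiophene would help to separate. As far as these compounds go, how an amine or a carboxylic acid on the phenyl ring would compare with methoxy and formyl also remains open.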